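The compounds below may be only part of what the source reports. "The series", "measured", "known", "first", "only" and "open" are said of these compounds alone.

Measured in a functional assay on L1210 cells (Mus musculus) for inhibition; a lower number here means a stronger inhibitor, a higher number a weaker inhibitor:
- compound 1 `CC(C)CN(CC(=O)N(CC(C)C)NC(=O)OCc1ccccc1)NC(=O)CBr`: 6500 nM
- compound 2 `CC(C)CN(CC(=O)N(CC(C)C)NC(=O)OCc1ccccc1)/N=C/c1ccccc1B(O)O`: 16200 nM
- compound 3 `CC(C)CN(NC(=O)OCc1ccccc1)C(=O)CN(Cc1ccccc1)/N=C/c1ccccc1B(O)O`: 27900 nM

Compound 2 is the starting point here. On one side of it lies a 2.5-fold higher number from compound 1 to compound 2 (0.40 log units; beyond the scatter). On the other lies a 1.7-fold higher number from compound 2 to compound 3 (0.24 log units; within the scatter), so it sits with compound 3 at the weaker end of this small set, and compound 1 stands apart from it.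

The next compound, compound 4 `CC(C)CN(CC(=O)N(Cc1ccccc1)NC(=O)OCc1ccccc1)/N=C/c1ccccc1B(O)O`, has not yet been measured. Its difference from compound 2 is phenyl in place of isopropyl on a saturated chain carbon bound to an amide-type nitrogen. In words, this is phenyl in place of isopropyl on a saturated chain carbon bound to an amide-type nitrogen, which also reads as isobutyl to benzyl.

The step that bears most directly on this is a 1.7-fold higher number from compound 2 to compound 3 (0.24 log units; within the scatter). It is the same replacement, but made on a saturated chain carbon bound to an amine nitrogen, so it is a guide and not a direct precedent. The other step, a 2.5-fold higher number from compound 1 to compound 2 (0.40 log units; beyond the scatter), concerns a different change and says little here. No step beyond the scatter is therefore expected, though a small move toward a higher number is possible.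

The expected change is a 1.3-fold higher number from compound 2 to compound 4 (0.11 log units; within the scatter). For compound 4 the estimated value is 21000 nM, with an expected range from 9500 nM to 46000 nM.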

Compound 4, half-maximal inhibitory concentration: 18400 nM
For compound 4 the middle estimate is 1.1-fold (0.06 log units) above the measured one; the measured number falls inside the stated range.
By their numbers in this assay, from the lowest: compound 1; then compounds 2, 4 and 3 (each within the scatter of the next).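

In this assay, going by these compounds alone, the change from isobutyl to benzyl on a saturated chain carbon bound to an amide-type nitrogen gives a 1.1-fold higher number from compound 2 to compound 4 (0.06 log units; within the scatter) and so cannot be told from the scatter; the earlier compounds showed nothing about this place. Read with a 1.7-fold higher number from compound 2 to compound 3 (0.24 log units; within the scatter) on a saturated chain carbon bound to an amine nitrogen, it means that the same replacement has now been seen on both kinds of nitrogen, and on neither does the step lie beyond the scatter. The compounds do show that, among these two groups, the number at this place gives no sign of depending on which one is present, but no measurement is available that explains this result.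

Isobutyl and benzyl are the only groups seen at this place, so it remains open whether a chain ending in an amine, a carboxylic acid or a longer chain such as hexyl would leave the number as unchanged as benzyl does. Going by these compounds, it also remains open how a compound carrying benzyl on both nitrogens would read, and whether benzyl on the amide-type nitrogen would behave the same way in a compound bearing the bromoacetyl group of compound 1.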